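From 4-methylphenyl to 3-(trifluoromethyl)phenyl in compound 4

The source may hold more compounds than are shown below. What is called first, only, known or untested is meant among the compounds shown, and "the series" means these compounds.

Values measured in a physicochemical assay for lipophilicity (on this read-out higher numbers stand for higher lipophilicity and lower numbers for lower lipophilicity), are these:
Compound 1 (`C=C(c1cccc2ccccc12)C1CCC2(CC1)COC(Nc1cccc(C(F)(F)F)c1)OO2`): 6.51
Compound 2 (`C=C(c1ccc2ccccc2c1)C1CCC2(CC1)COC(Nc1ccc(F)cc1)OO2`): 5.75
Compound 3 (`C=C(c1ccc2ccccc2c1)C1CCC2(CC1)COC(Nc1ccc(C)cc1)OO2`): 6.08

Compound 3 stands second highest of the three, with 6.08 as its value. Compound 2 lies lower at 5.75 and compound 1 lies higher at 6.51 and both gaps are beyond the scatter.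

Compound 4 (`C=C(c1ccc2ccccc2c1)C1CCC2(CC1)COC(Nc1cccc(C(F)(F)F)c1)OO2`) has 3-(trifluoromethyl)phenyl in place of 4-methylphenyl on an amine nitrogen and otherwise matches compound 3. For the measured compounds named here, the one measured step on this aryl group is a number 0.33 log units higher from compound 2 to compound 3 (beyond the scatter) for methyl in place of fluoro on an aromatic carbon, a modest step but a different swap. Compound 1 carries the entering group and reads 6.51 in this comparison, but it differs from compound 4 elsewhere and is only a guide. A modest rise in this assay is therefore expected. The expected move is a number 0.42 log units higher from compound 3 to compound 4 (beyond the scatter) and would be of similar size to the measured step. Compound 4 is estimated at 6.5 with an expected range of 6.2 to 6.8 as its bounds.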

Compound 4, partition coefficient: 6.51
The estimate for compound 4 lay 0.01 log units below the measured number, and the stated range covers the measured number.
By their numbers in this assay, from the lowest: compound 2; then compound 3; then compounds 1 and 4 (each within the scatter of the next).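

In this assay the change on the amine nitrogen to 3-(trifluoromethyl)phenyl gives a number 0.43 log units higher from compound 3 to compound 4 (beyond the scatter) when it replaces 4-methylphenyl and a number 0.76 log units higher from compound 2 to compound 4 (beyond the scatter) when it replaces 4-fluorophenyl, which places all three aryl groups in one order on the same core, with 4-fluorophenyl lowest and 3-(trifluoromethyl)phenyl highest. At the other varied place, naphthalen-2-yl in place of naphthalen-1-yl on the double-bonded chain carbon gives no change at the digits printed from compound 1 to compound 4 (within the scatter) in this one pair, so that swap leaves the read-out unmoved here. Nothing at hand explains either result.

The compounds shown leave open whether the order of the aryl groups also holds with naphthalen-1-yl in the molecule. They also leave open how a methoxy group or a carboxylic acid on the phenyl ring would read in this assay on this core.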